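This account rests on a few compounds, and the source may have more. Where it says the series, first, only, none or still open, it means among the compounds named here.

Three compounds share one core, a substituted aniline carrying an ethyl group and a nitrile, and differ only in the ring attached to the other aromatic carbon. Compound 1 `CCN(c1ccc(C#N)c(Cl)c1)c1cc(-c2cncnc2)ccc1C` carries a pyrimidine, compound 2 `CCN(c1ccc(C#N)c(Cl)c1)c1cc(-n2ccnc2)ccc1C` an imidazole, and compound 3 `CCN(c1ccc(C#N)c(Cl)c1)c1cc(-n2cnc3ccccc32)ccc1C` a benzimidazole. The measurement of interest is an ADME assay on L02 cells (Homo sapiens) for antiproliferative activity, read by CCK-8 assay, with a stated time of 6 days (a lower number here means a stronger inhibitor, a higher number a weaker inhibitor), a test of how strongly a compound slows the growth of normal human liver cells. Only compound 2 has a number here: compound 2 gives 15000 nM, a weak effect. In this assay compound 1 gives "not determined" (no result reported) and compound 3 gives "not determined" (no result reported), so neither has a number and compound 3 cannot be placed on this scale; the only anchor is the weak value of compound 2.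

Compound 4 `CCN(c1ccc(C#N)c(Cl)c1)c1cc(-c2ccnn2C)ccc1C` is the next variant. Relative to compound 3 the change is 1-methyl-1H-pyrazol-5-yl in place of 1H-benzimidazol-1-yl on an aromatic carbon. Among the compounds with values here, no measured step exists that matches this change. Given that the one number known for this series is weak, and that no change of this kind has been measured, compound 4 is expected to show a value near that weak level, roughly 15000 nM, with a plausible range from 5000 nM to 45000 nM.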

Compound 4, half-maximal inhibitory concentration: 6230 nM
Estimate against measurement, compound 4: 2.4-fold (0.38 log units) above; the measured number falls inside the stated range.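

In this assay, putting 1-methyl-1H-pyrazol-5-yl in place of 1H-imidazol-1-yl on this aromatic carbon gives a 2.4-fold lower number from compound 2 to compound 4 (0.38 log units; beyond the scatter), the first sign that the ring at this position can shift the number by more than the usual scatter, though only modestly. The step from compound 3 to compound 4 cannot be read, as compound 3 has no number to start from. Nothing measured here explains the shift.

The compounds shown leave open how much of the step comes from the methyl group and how much from the ring itself. Also open, on these data alone, is whether an amine or a carboxylic acid on this aromatic carbon would move the number in this assay further than either ring does.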